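The source may report more compounds than this note shows. Statements on the series, on what has been measured and on what is new or still open speak of the compounds shown alone.

Compound 3 `COc1ccc(OC(C)(C)C2OCC(C/C=C\CCC(=O)O)C(c3cccnc3)O2)cc1` carries a 4-methoxyphenyl on the oxygen of its side chain. In an assay for inhibition of prostacyclin synthase (Homo sapiens), using microsomes (on this read-out lower numbers stand for stronger inhibition and higher numbers for weaker inhibition), compound 3 gives > 100000 nM, which is a limit of the assay and not a number. Compound 1 `N#Cc1ccccc1C1OCC(C/C=C\CCC(=O)O)C(c2cccnc2)O1` also stands at a limit in this assay, giving > 100000 nM. Compound 2 `O=C(O)CC/C=C\CC1COC(c2ccc([N+](=O)[O-])cc2)OC1c1cccnc1` gives 13000 nM in this assay. Among the measured compounds shown here, the one measured step, an at least 7.6-fold lower number from compound 1 to compound 2 (0.88 log units; beyond the scatter), changes the aryl group on the saturated ring carbon and begins at the limit of > 100000 nM in this assay, at which 2 of the 3 values shown sit; it does not touch the group on the oxygen. Compound 4 `CC(C)(Oc1ccccc1F)C1OCC(C/C=C\CCC(=O)O)C(c2cccnc2)O1` differs from compound 3 by 2-fluorophenyl in place of 4-methoxyphenyl on an oxygen on a saturated carbon. For the measured compounds named here, no measured step bears on this change, and compound 3 itself offers only a limit, so there is no measured ground for expecting a step beyond the scatter in either direction. The expected step is a number no higher from compound 3 to compound 4 (the limit leaves the size open). Compound 4 is therefore estimated to show weak inhibition, at about 100000 nM, with a range from 20000 nM to 400000 nM.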

Compound 4, half-maximal inhibitory concentration: < 1000 nM
Compound 4: a limit, no number (the forecaster's own chance of this, stated with the estimate: 65%); at least 100-fold (2.00 log units) between middle value and limit.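

In this assay, among the compounds shown here, the change on the oxygen of the side chain gives an at least 100-fold lower number from compound 3 to compound 4 (2.00 log units; beyond the scatter), showing that the group at this place can shift the read-out strongly, whereas the one earlier step concerned only the aryl group on the saturated ring carbon. The value of compound 4 is a limit and not a number, so its actual strength remains unfixed: the limit of < 1000 nM in this assay, at which 1 of the 4 values shown sits. The value of compound 3 is also a limit, so the true size of the step remains unfixed from this end too: the limit of > 100000 nM in this assay, at which 2 of the 4 values shown sit.

Since 2-fluorophenyl and 4-methoxyphenyl differ in more than one respect, the compounds shown cannot say whether gaining the fluorine or losing the methoxy matters, and an unsubstituted phenyl on the same oxygen would help to separate the two. Also open, as far as these compounds go, is whether an amide could replace the carboxylic acid shared by all four compounds.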